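Aryl ether series: trifluoromethyl for ethyl on the oxygen

This account rests on a few compounds, and the source may have more. Where it says the series, first, only, none or still open, it means among the compounds named here.

The three measured compounds share one core and differ only in the group carried on the oxygen of the aromatic ring. Compound 1 `CC(C)=CCC/C(C)=C/COc1ccc(C2CC2C(=O)NNC(=O)c2ccncc2)cc1` gives 78000 nM in a functional assay on A549 cells (Homo sapiens) for inhibition, read by MTT assay, with a stated time of 72 h; a lower number here means a stronger inhibitor, a higher number a weaker inhibitor; compound 2 `O=C(NNC(=O)C1CC1c1ccc(OCC(F)(F)F)cc1)c1ccncc1` gives 10000 nM; compound 3 `CCOc1ccc(C2CC2C(=O)NNC(=O)c2ccncc2)cc1` gives 43000 nM. Compound 3 thus holds the second highest of the three numbers: its nearest neighbour is compound 1, with a 1.8-fold lower number from compound 1 to compound 3 (0.26 log units; within the scatter), and the only separation beyond the scatter is to compound 2, with a 4.3-fold higher number from compound 2 to compound 3 (0.63 log units; beyond the scatter).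

Compound 4 `O=C(NNC(=O)C1CC1c1ccc(OC(F)(F)F)cc1)c1ccncc1` is formed from compound 3 by trifluoromethyl in place of ethyl on an oxygen on an aromatic ring. Among the measured compounds shown here, the steps that bear on it are those in which a trifluoromethyl replaces another group on the saturated chain carbon bound to that oxygen: a 7.8-fold lower number from compound 1 to compound 2 (0.89 log units; beyond the scatter) and the reverse of a 4.3-fold higher number from compound 2 to compound 3 (0.63 log units; beyond the scatter), both modest and both beyond the scatter, each pointing to a lower number when the trifluoromethyl enters. Here the trifluoromethyl sits directly on the oxygen rather than one carbon out, so the data give no exact precedent, and a somewhat smaller step is taken as the working expectation. The expected step is a 2.9-fold lower number from compound 3 to compound 4 (0.46 log units; beyond the scatter), downward. Compound 4 is therefore estimated at 15000 nM, with a range from 5000 nM to 45000 nM.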

Compound 4, half-maximal inhibitory concentration: 56000 nM
Compound 4: the middle estimate sits 3.7-fold (0.57 log units) below what was measured; the whole stated range lies below it.
By their numbers in this assay, from the lowest: compound 2; then compounds 3, 4 and 1 (each within the scatter of the next).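

In this assay, ethoxy gives way to trifluoromethoxy with a 1.3-fold higher number from compound 3 to compound 4 (0.11 log units; within the scatter), so on this oxygen trifluoromethyl brings no separation from ethyl. The trifluoromethoxy group also stays close to the much larger ether chain, with a 1.4-fold lower number from compound 1 to compound 4 (0.14 log units; within the scatter), whereas the 2,2,2-trifluoroethyl group stands clear of it, with a 5.6-fold higher number from compound 2 to compound 4 (0.75 log units; beyond the scatter) on going to trifluoromethyl. The lower number therefore belongs to compound 2 alone among these ethers, and compound 4 goes against any reading that a trifluoromethyl in this part of the molecule lowers the number in general. Nothing shown here gives a reason for the difference between the two fluorinated groups.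

On these data alone, it remains open whether the lower number of compound 2 would hold with a longer fluorinated chain such as 3,3,3-trifluoropropyl or with a 2,2-difluoroethyl group. As far as these compounds go, it is equally open how an amine or a carboxylic acid at the end of the ethyl chain would read in this assay, so the limits of this position are still undefined.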